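This account rests on a few compounds, and the source may have more. Where it says the series, first, only, none or still open, it means among the compounds named here.

Working notes on the series. Compound 3 `c1cc2[nH]cc(CCCN3CCNCC3)c2cc1-n1cnnc1` is the secondary amine of the set and in an assay on CHO cells for displacement of a labelled ligand from 5-hydroxytryptamine receptor 1D (Homo sapiens) (on this read-out higher numbers stand for weaker inhibition and lower numbers for stronger inhibition), compound 3 gives 31 nM, the highest number of the three; compound 2 `CC(=O)Nc1ccc(CN2CCN(CCCc3c[nH]c4ccc(-n5cnnc5)cc34)CC2)cc1` gives 2.5 nM and compound 1 `c1coc(CN2CCN(CCCc3c[nH]c4ccc(-n5cnnc5)cc34)CC2)c1` gives 0.4 nM, both beyond the scatter from compound 3.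

Compound 4 `c1ccc(N2CCN(CCCc3c[nH]c4ccc(-n5cnnc5)cc34)CC2)cc1` differs from compound 3 by phenyl in place of hydrogen on an amine nitrogen in a ring, an aryl group bound straight to the ring nitrogen rather than through a saturated chain carbon as in compounds 1 and 2.

Among the measured compounds shown here, two measured steps bear on it, both in the same direction. Removing the (furan-2-yl)methyl group from the ring nitrogen gave a 78-fold higher number from compound 1 to compound 3 (1.89 log units; beyond the scatter); read in reverse, adding that group is a large fall in number. Adding 4-acetamidobenzyl gave a 12-fold higher number from compound 2 to compound 3 (1.09 log units; beyond the scatter) in the recorded direction. Both substitutions on the ring nitrogen lowered the number well beyond the scatter. Phenyl lacks the chain carbon of either group, so the size is uncertain, but a step toward lower numbers is expected, estimated at a 7.8-fold lower number from compound 3 to compound 4 (0.89 log units; beyond the scatter). Compound 4 is therefore expected to give about 4 nM, with a range of 1 nM to 15 nM.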

Compound 4, half-maximal inhibitory concentration: 1.4 nM
Beside the measured number, compound 4's estimate is 2.9-fold (0.46 log units) above it, and the stated range covers the measured number.
By their numbers in this assay, from the lowest: compound 1; then compounds 4 and 2 (each within the scatter of the next); then compound 3.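

On the amine nitrogen of the six-membered non-aromatic ring, a saturated chain carbon is not needed for a large fall in number: in this assay there is a 22-fold lower number from compound 3 to compound 4 (1.35 log units; beyond the scatter) with phenyl bound straight to the ring nitrogen. The result also shows that a substituent with 0 hydrogen-bond donors and 0 hydrogen-bond acceptors is enough for a step of this kind, and phenyl cannot be separated from 4-acetamidobenzyl on this read-out, with a 1.8-fold lower number from compound 2 to compound 4 (0.25 log units; within the scatter) as the step. (Furan-2-yl)methyl remains distinct from phenyl, with a 3.5-fold higher number from compound 1 to compound 4 (0.54 log units; beyond the scatter) as the step, so the choice of group on this nitrogen can still be read beyond the scatter, at least for this pair.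

No measurement shown gives a reason for any of these differences. On these data alone, it remains open how an amine or a carboxylic acid on the phenyl ring would move the number, and whether a longer chain carrying the phenyl on the ring nitrogen would follow (furan-2-yl)methyl or stay with phenyl and 4-acetamidobenzyl.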